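The compounds below may be only part of what the source reports. "The series", "measured", "known", "first", "only" and "open" are said of these compounds alone.

Compound 2 `COc1ccc2c(c1)c(S(=O)(=O)c1cccc(F)c1)cn2C1CCCNC1` gives 10.7 nM in an assay on HeLa cells for displacement of a labelled ligand from 5-hydroxytryptamine receptor 6 (Homo sapiens), with a stated time of 2 h; on this read-out lower numbers stand for stronger inhibition and higher numbers for weaker inhibition. Its number sits between those of compound 1 `O=S(=O)(c1cccc(F)c1)c1cn(C2CCCNC2)c2ccccc12`, which gives 6 nM, and compound 3 `CCN1CCCC(n2cc(S(=O)(=O)c3cccc(F)c3)c3cc(OC)ccc32)C1`, which gives 16 nM; both gaps lie within the scatter. Compound 4 `O=S(=O)(c1cccc(F)c1)c1cn(C2CCCNC2)c2ccc(F)cc12` differs from compound 2 by fluoro in place of methoxy on an aromatic carbon. The measured step that bears on this position is a 1.8-fold higher number from compound 1 to compound 2 (0.25 log units; within the scatter), in which the methoxy group entered; the step of a 1.5-fold higher number from compound 2 to compound 3 (0.17 log units; within the scatter) concerns the ring amine and is not comparable. Among the measured compounds shown here, no measured step exchanges methoxy for fluoro. Because a 1.8-fold higher number from compound 1 to compound 2 (0.25 log units; within the scatter) stayed within the scatter, no step beyond the scatter is expected in this assay for compound 4. Compound 4 is therefore expected to give 8 nM, within 3 nM to 20 nM. The expected step is a 1.3-fold lower number from compound 2 to compound 4 (0.13 log units; within the scatter).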

Compound 4, inhibition constant: 4 nM
Compound 4: the middle estimate sits 2.0-fold (0.30 log units) above what was measured, within the range that was stated.
By their numbers in this assay, from the lowest: compounds 4, 1, 2 and 3 (each within the scatter of the next, the first and the last beyond it).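

In this assay, among the compounds shown here, the group at this position can move the number beyond the scatter: a 2.7-fold lower number from compound 2 to compound 4 (0.43 log units; beyond the scatter) is the only step here that does so, and it is modest. Neither group separates from hydrogen at this place, since a 1.8-fold higher number from compound 1 to compound 2 (0.25 log units; within the scatter) and a 1.5-fold lower number from compound 1 to compound 4 (0.18 log units; within the scatter) both stay within the scatter, so only the exchange of methoxy for fluoro shows a difference. Nothing shown accounts for that difference.

The compounds shown leave open how a chloro, nitrile or amine group at this position would compare with fluoro. They also leave open whether ethyl on the ring amine of compound 4 would give a step like a 1.5-fold higher number from compound 2 to compound 3 (0.17 log units; within the scatter) in the methoxy series.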